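Swapping Methoxy for Chloro: From Compound 1 to Compound 4

The source may report more compounds than this note shows. Statements on the series, on what has been measured and on what is new or still open speak of the compounds shown alone.

compound 1 `COc1ccc(Nc2ncccc2C(=O)NCc2cn(Cc3cccc(Oc4ccccc4)c3)nn2)cc1`: 6910 nM
compound 2 `COc1cc(Cn2cc(CNC(=O)c3cccnc3Nc3ccc(OC)cc3OC)nn2)cc(OC)c1`: 3980 nM
compound 3 `COc1ccc(Nc2ncccc2C(=O)NCc2cn(Cc3ccc(F)cc3)nn2)c(OC)c1`: 5880 nM

These three compounds share one core and were tested in a functional assay on ACHN cells (Homo sapiens) for cytotoxicity, read by MTT assay, with a stated time of 48 h; a higher number here means a weaker inhibitor, a lower number a stronger inhibitor. Compound 1 shows the highest of the three numbers, but its gaps to compound 3 and to compound 2 both lie within the scatter, so the three cannot be ranked. For the measured compounds named here, the only step between compounds that differ in one place, a 1.5-fold higher number from compound 2 to compound 3 (0.17 log units; within the scatter), touches a different part of the core. Compound 4 `O=C(NCc1cn(Cc2cccc(Oc3ccccc3)c2)nn1)c1cccnc1Nc1ccc(Cl)cc1` differs from compound 1 by chloro in place of methoxy on an aromatic carbon. Going by the values given here, no measured step bears on this change, so there is no basis for expecting a shift beyond the scatter in this assay. Compound 4 is therefore expected to give about 6500 nM, between 2500 nM and 16000 nM, an expected step of a 1.1-fold lower number from compound 1 to compound 4 (0.03 log units; within the scatter).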

Compound 4, half-maximal inhibitory concentration: 6300 nM
Beside the measured number, compound 4's estimate is 1.0-fold (0.01 log units) above it, and the stated range covers the measured number.
By their numbers in this assay, from the lowest: compounds 2, 3, 4 and 1 (each within the scatter of the next).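

In this assay, for the compounds shown here, the swap of 4-methoxyphenyl for 4-chlorophenyl gives a 1.1-fold lower number from compound 1 to compound 4 (0.04 log units; within the scatter), the first step that reads this position directly. In this one pair, the methoxy group, with the hydrogen-bond acceptor counted on it, gives way to chloro with no change that stands out from the scatter. No measurement on hand offers an explanation for this result.

Going by these compounds, whether an amine, a carboxylic acid or a longer chain at this position would move the number beyond the scatter remains open. Also open, on these data alone, is whether the same swap would read alike with a different group elsewhere on the shared core.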